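A few compounds are considered here, and "the series" means these few. Any claim that something is new, unique, unknown or untested is made for them only; others in the source may bear on it.

Measured so far in a functional assay on MGC-803 cells (Homo sapiens) for inhibition, read by MTT assay, with a stated time of 48 h; a higher number here means a weaker inhibitor, a lower number a stronger inhibitor:
Compound 1 `C/C=C/C(=O)N(Cc1ccc(OC)c([N+](=O)[O-])c1)c1cc(OC)c(OC)c(OC)c1` gives 590 nM
Compound 2 `COc1ccc(CNc2cc(OC)c(OC)c(OC)c2)cc1[N+](=O)[O-]` gives 19400 nM
Compound 3 `COc1ccc(CN(C(=O)C=C(C)C)c2cc(OC)c(OC)c(OC)c2)cc1O` gives 320 nM

Compound 1, at 590 nM, lies within the usual scatter of compound 3, at 320 nM. Compound 2 stands far off, with a 33-fold higher number from compound 1 to compound 2 (1.52 log units; beyond the scatter). The next compound to be tested is compound 4 `C/C=C/C(=O)N(Cc1ccc(OC)c(OC)c1)c1cc(OC)c(OC)c(OC)c1`, which keeps the core of compound 1 and changes one group: methoxy in place of nitro on an aromatic carbon, ortho to a methoxy group and meta to a large group (methoxy in place of nitro on an aromatic carbon) .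

Among the compounds with values here, no measured step covers this swap. Within the data shown here, the only step available, a 33-fold higher number from compound 1 to compound 2 (1.52 log units; beyond the scatter), is large, but it removes the (prop-1-en-1-yl)carbonyl group from the nitrogen and leaves the nitro group in place, so it says little about the new change. Compound 3 offers a weak hint: it has no nitro group and still gives 320 nM, although its chain on the nitrogen differs too. The nitro group therefore does not look essential, and no shift beyond the scatter is expected in this assay, though the uncertainty is wide.

The expected result is a 1.2-fold lower number from compound 1 to compound 4 (0.07 log units; within the scatter). For compound 4 the estimated value is 500 nM, with an expected range from 150 nM to 1700 nM.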

Compound 4, half-maximal inhibitory concentration: 20100 nM
Estimate against measurement, compound 4: 40-fold (1.60 log units) below, and the stated range ends below it.
By their numbers in this assay, from the lowest: compounds 3 and 1 (each within the scatter of the next); then compounds 2 and 4 (each within the scatter of the next).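

The swap of nitro for methoxy, on an aromatic carbon ortho to a methoxy group, changes only 3 heavy atoms for 2, yet in this assay it gives a 34-fold higher number from compound 1 to compound 4 (1.53 log units; beyond the scatter). Within the data shown here, until now, the only single change on record was at the nitrogen, a 33-fold higher number from compound 1 to compound 2 (1.52 log units; beyond the scatter), so this result adds a second place where one change moves the number by a large step: the ring position is not indifferent to which group it carries, even with the (prop-1-en-1-yl)carbonyl group kept on the nitrogen. No measurement shown here accounts for the size of this step.

The compounds shown leave open whether the nitro group itself is needed, since compound 3, at 320 nM, has a hydroxy group at this place but also a different chain on the nitrogen, so it differs from compound 1 and compound 4 in more than one place. Also open, as far as these compounds go, is how other groups at this position would behave, such as a plain hydrogen, an amine or a nitrile, with the rest of compound 1 unchanged.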